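This account rests on a few compounds, and the source may have more. Where it says the series, first, only, none or still open, it means among the compounds named here.

In a functional assay on HL-60 cells (Homo sapiens), read by calcium flux (on this read-out lower numbers stand for an effect already at smaller amounts and higher numbers for an effect only at larger amounts of compound), three compounds have been measured so far, and none of them gives a number. Compound 1 (`CCc1cc(Cc2cccc(OC)c2)c(=O)n(CC(=O)Nc2ccc(I)cc2)n1`) gives > 50000 nM, which is a limit of the assay. Compound 2 (`COc1ccc(Cc2cc(-c3ccc(Cl)cc3)nn(CC(=O)Nc3ccc(Br)cc3)c2=O)cc1`) gives > 50000 nM, also a limit. Compound 3 (`Cc1cc(Cc2ccc(C(F)(F)F)cc2)c(=O)n(CC(=O)Nc2ccc(Br)cc2)n1`) gives > 50000 nM, again a limit and not a number. The whole record therefore reads: the limit of > 50000 nM in this assay, at which 3 of the 3 values shown sit. Compound 3 thus stands with the other two, and the data do not rank the three against one another.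

Compound 4 (`Cc1cc(Cc2ccc(C#N)cc2)c(=O)n(CC(=O)Nc2ccc(Br)cc2)n1`) departs from compound 3 in a single place: cyano in place of trifluoromethyl on an aromatic carbon. The trifluoromethyl group of compound 3 is thus replaced by a cyano group in compound 4, para to a large group. Among the measured compounds shown here, no measured pair differing in one place is available in this assay as a guide to the size of such a change. The expectation rests on compound 3, which sits at the limit of > 50000 nM, and on the same limit for compound 1 and compound 2. No step beyond the scatter is expected in either direction, and another limit is the likeliest report. The expected change is an at least 1.1-fold lower number from compound 3 to compound 4 (0.04 log units; that floor lies within the scatter). For compound 4 the estimated value is 45000 nM, with an expected range from 12000 nM to 50000 nM.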

Compound 4, half-maximal effective concentration: > 50000 nM
Compound 4 was reported as a limit; the forecaster's own chance of this, stated with the estimate: 75%; middle value at least 1.1-fold (0.04 log units) away from the limit.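

In this assay compound 4 gives > 50000 nM as a limit and not a number. Among the compounds shown here, compound 3 sits at a limit as well, so no step from compound 3 to compound 4 can be read. The compounds shown leave open how cyano and trifluoromethyl compare here, and whether in this assay any compound with this shared core gives a number at all.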